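Aryl methyl to methoxy on the thiazolylidene amine series

This account rests on a few compounds, and the source may have more. Where it says the series, first, only, none or still open, it means among the compounds named here.

Measured so far:
compound 1, `COc1ccc(-n2nc(C(C)=O)s/c2=N\c2nc(-c3c(C)n(C)n(-c4ccccc4)c3=O)cs2)cc1`, 41300 nM
compound 2, `CCOC(=O)c1nn(-c2ccc(C)cc2)/c(=N/c2nc(-c3c(C)n(C)n(-c4ccccc4)c3=O)cs2)s1`, > 100000 nM

In a functional assay on HepG2 cells (Homo sapiens) for cytotoxicity, read by sulforhodamine B assay, with a stated time of 72 h (on this read-out higher numbers stand for weaker inhibition and lower numbers for stronger inhibition), compound 1 gives 41300 nM. For compound 2 the same assay reports only a limit, > 100000 nM; this is the assay limit, as noted in the limit of > 100000 nM in this assay, at which 1 of the 2 values shown sits, not a number. Compound 2 thus stands at the weak end of the pair shown. Compound 3, `CCOC(=O)c1nn(-c2ccc(OC)cc2)/c(=N/c2nc(-c3c(C)n(C)n(-c4ccccc4)c3=O)cs2)s1`, carries methoxy in place of methyl on an aromatic carbon, (methoxy in place of methyl on an aromatic carbon). For the measured compounds named here, no measured pair isolates this change, so no step beyond the scatter is expected: an at least 1.1-fold lower number from compound 2 to compound 3 (0.04 log units; that floor lies within the scatter). Compound 3 is estimated at 90000 nM, with a range from 35000 nM to 250000 nM.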

Compound 3, half-maximal inhibitory concentration: 12900 nM
Estimate against measurement, compound 3: 7.0-fold (0.84 log units) above; the measured number lies below the stated range.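

With the ethoxy on the carbonyl carbon held, 4-methylphenyl to 4-methoxyphenyl gives an at least 7.7-fold lower number from compound 2 to compound 3 (0.88 log units; beyond the scatter) in this assay, so this position on the aromatic ring does respond to the change. The value of compound 2 is a limit and not a number, so that step has only a floor: the limit of > 100000 nM in this assay, at which 1 of the 3 values shown sits.
With 4-methoxyphenyl held, ethoxy in place of methyl on a carbonyl carbon gives a 3.2-fold lower number from compound 1 to compound 3 (0.51 log units; beyond the scatter), so the carbonyl substituent also moves the read-out.

Open, as far as these compounds go, is whether an amine or a chlorine at the methoxy place would follow the same direction. Also open, from the compounds shown here alone, is how a carboxylic acid or a longer chain on the carbonyl carbon would read.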